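Cytotoxicity in Liver Cells After Swapping an Amine Side Chain

A few compounds are considered here, and "the series" means these few. Any claim that something is new, unique, unknown or untested is made for them only; others in the source may bear on it.

In an ADME assay on HepG2 2.2.15 cells (Homo sapiens) for cytotoxicity (on this read-out higher numbers stand for lower toxicity in this test and lower numbers for higher toxicity in this test), compound 1 `O=C(Nc1ncc(Cc2ccc(Br)cc2)s1)c1ccc2ccccc2c1` returns only a limit of the test, > 50000 nM, and not a number. Compound 2 `CCCCC(CC)CNc1ncc(C(Oc2ccc3cc(Br)ccc3c2)c2ccc(Cl)cc2)s1` is reported in this assay as "not toxic" (no number reported), again without a figure, so compound 2 cannot be placed on a numerical scale; what the two entries show is that (the limit of > 50000 nM in this assay, at which 1 of the 2 values shown sits), and compound 2 keeps company with it on the side of low toxicity. Compound 3 `COCCNc1ncc(C(Oc2ccc3cc(Br)ccc3c2)c2ccc(Cl)cc2)s1` has not yet been measured in this assay. It differs from compound 2 in a single place: methoxymethyl in place of 1-ethylpentyl on a saturated chain carbon bound to a nitrogen on an aromatic ring. Going by the values given here, no measured pair follows this particular change, so its effect is untested; the expected step is none beyond the usual scatter, in neither direction. Because compound 2 is reported as "not toxic" (no number reported) in this assay, compound 3 is expected to remain at the harmless end as well. The likeliest outcome is that this assay once more reports no number but only the top of its measurable range. Compound 3 is estimated at 50000 nM in this assay, within a range from 20000 nM to 100000 nM.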

Compound 3, half-maximal cytotoxic concentration: "not toxic" (no number reported)
Compound 3: no number reported, so the estimate cannot be set against anything.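

Compound 2 and compound 3 are both reported as "not toxic" without a number in this assay, so no step can be read between them. The compounds shown leave open whether replacing 2-ethylhexyl with 2-methoxyethyl on the amine changes cytotoxicity at all, and at what concentration, if any, either compound would become toxic to these cells.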